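This account rests on a few compounds, and the source may have more. Where it says the series, first, only, none or still open, it means among the compounds named here.

Within the data shown here, compound 1 `CN(C)c1ccc(C(=O)N2CCC(NS(=O)(=O)c3cc(S(=O)(=O)c4ccccc4)ccc3C(F)(F)F)CC2)cc1` was tested in a physicochemical assay for solubility (a lower number here means a less soluble compound, a higher number a more soluble compound), where compound 1 gives 50000 nM, one of only two numbers so far and within the scatter of the other. That other is compound 2 `O=C(C1CCNCC1)N1CCC(NS(=O)(=O)c2cc(S(=O)(=O)c3ccccc3)ccc2C(F)(F)F)CC1`, which in this assay gives 100000 nM; the step between them is a 2.0-fold higher number from compound 1 to compound 2 (0.30 log units; within the scatter). Compound 3 `O=C([C@H]1CCNC1)N1CCC(NS(=O)(=O)c2cc(S(=O)(=O)c3ccccc3)ccc2C(F)(F)F)CC1` differs from compound 1 by pyrrolidin-3-yl in place of 4-(dimethylamino)phenyl on a carbonyl carbon, a change of the same kind as that earlier step. That measured step stayed within the scatter, so a step of similar size is expected here, a 2.0-fold higher number from compound 1 to compound 3 (0.30 log units; within the scatter). Compound 3 is therefore expected to give about 100000 nM, between 40000 nM and 250000 nM.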

Compound 3, solubility: 25000 nM
Compound 3: the middle estimate sits 4.0-fold (0.60 log units) above what was measured, outside the stated range (below it).
By their numbers in this assay, from the lowest: compounds 3, 1 and 2 (each within the scatter of the next, the first and the last beyond it).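

Pyrrolidin-3-yl in place of piperidin-4-yl on a carbonyl carbon gives a 4.0-fold lower number from compound 2 to compound 3 (0.60 log units; beyond the scatter) in this assay and is the first step at this position to pass the scatter. Pyrrolidin-3-yl in place of 4-(dimethylamino)phenyl gives a 2.0-fold lower number from compound 1 to compound 3 (0.30 log units; within the scatter) and so shows that piperidin-4-yl and pyrrolidin-3-yl, although both are small rings with one nitrogen, are not interchangeable here. Nothing shown explains this difference. Still open, on these data alone, is whether the mirror-image form of pyrrolidin-3-yl gives a similar number, and how an azetidine ring or a carboxylic acid would read at this position.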